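Replacing 3-bromophenyl with 4-methoxyphenyl on a carbonyl carbon

The compounds below may be only part of what the source reports. "The series", "measured", "known", "first", "only" and "open" are said of these compounds alone.

Measured compounds:
compound 1, `COc1ccc(/C=C/c2cc(OC)cc(OC)c2/C=C/C(=O)c2ccc(C)cc2)cc1`, 4.8 ug/mL
compound 2, `COc1ccc(/C=C/c2cc(OC)cc(OC)c2/C=C/C(=O)c2cccc(Br)c2)cc1`, 13 ug/mL
compound 3, `COc1ccc(/C=C/c2cc(OC)cc(OC)c2/C=C/C(=O)c2ccccc2C)cc1`, 5.3 ug/mL

In a functional assay on HepG2 cells (Homo sapiens) for antiproliferative activity, read by MTT assay, with a stated time of 48 h (a higher number here means a weaker inhibitor, a lower number a stronger inhibitor), compound 2 gives the highest of the three numbers. The step of a 2.7-fold higher number from compound 1 to compound 2 (0.43 log units; beyond the scatter) and the step of a 2.5-fold lower number from compound 2 to compound 3 (0.39 log units; beyond the scatter) both place compound 2 apart from the other two, while compound 1 and compound 3 lie within the scatter of each other, as the step of a 1.1-fold higher number from compound 1 to compound 3 (0.04 log units; within the scatter) shows.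

Compound 4, `COc1ccc(/C=C/c2cc(OC)cc(OC)c2/C=C/C(=O)c2ccc(OC)cc2)cc1`, has not been measured. It differs from compound 2 in one place: 4-methoxyphenyl in place of 3-bromophenyl on a carbonyl carbon. Among the compounds with values here, no measured step carries a methoxy group, so the change is only partly covered. The two steps that bear on it are those that leave 3-bromophenyl: a 2.7-fold higher number from compound 1 to compound 2 (0.43 log units; beyond the scatter) and a 2.5-fold lower number from compound 2 to compound 3 (0.39 log units; beyond the scatter), both modest and both pointing away from compound 2 toward lower numbers. A step of that size is therefore expected in this assay, downward, as a 2.4-fold lower number from compound 2 to compound 4 (0.37 log units; beyond the scatter). Compound 4 is estimated at 5.5 ug/mL, with a range from 2.5 ug/mL to 12 ug/mL.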

Compound 4, half-maximal inhibitory concentration: 4.9 ug/mL
For compound 4 the middle estimate is 1.1-fold (0.05 log units) above the measured one; the range from low to high includes it.
By their numbers in this assay, from the lowest: compounds 1, 4 and 3 (each within the scatter of the next); then compound 2.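

In this assay, 4-methoxyphenyl on the carbonyl carbon also leaves 3-bromophenyl behind (a 2.7-fold lower number from compound 2 to compound 4 (0.42 log units; beyond the scatter)), so three different replacements now separate compound 2 from the rest by steps of similar size. Methoxy in place of methyl on an aromatic carbon changes nothing that can be told from the scatter (a 1.0-fold higher number from compound 1 to compound 4 (0.01 log units; within the scatter)), and neither does 4-methoxyphenyl in place of 2-methylphenyl (a 1.1-fold lower number from compound 3 to compound 4 (0.03 log units; within the scatter)). Among these four compounds, 3-bromophenyl alone stands apart as the weakest, while 4-methylphenyl, 2-methylphenyl and 4-methoxyphenyl cannot be separated.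

Nothing shown gives a reason for the standing of compound 2.

Going by these compounds, what 4-bromophenyl would give remains open, as does the effect of an amine or a carboxylic acid on this ring.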